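Furan Isomers on a Ribose-Bearing Bicyclic Core

The source may report more compounds than this note shows. Statements on the series, on what has been measured and on what is new or still open speak of the compounds shown alone.

Compound 1 `O=c1[nH]cnc2c1c(-c1ccoc1)cn2[C@@H]1O[C@H](CO)[C@@H](O)[C@H]1O` carries a furan-3-yl group on its core. In a functional assay on HeLa S3 cells (Homo sapiens) for antiproliferative activity, read by XTT assay, with a stated time of 72 h (a higher number here means a weaker inhibitor, a lower number a stronger inhibitor), compound 1 gives only a limit of the assay, > 20000 nM. Compound 2 `O=c1[nH]cnc2c1c(-c1ccco1)cn2[C@@H]1O[C@H](CO)[C@@H](O)[C@H]1O` is the same molecule except for (furan-2-yl in place of furan-3-yl on an aromatic carbon); in this assay compound 2 gives 5780 nM, which is an at least 3.4-fold lower number from compound 1 to compound 2 (0.53 log units; beyond the scatter). Compound 3 `COc1nc(N)nc2c1c(-c1ccoc1)cn2[C@@H]1O[C@H](CO)[C@@H](O)[C@H]1O` bears a different core, and the difference between the two cores is not broken down here. In this assay compound 3 gives only a limit, > 20000 nM. This is the limit of > 20000 nM in this assay, at which 2 of the 3 values shown sit. Compound 4 `COc1nc(N)nc2c1c(-c1ccco1)cn2[C@@H]1O[C@H](CO)[C@@H](O)[C@H]1O` differs from compound 3 by furan-2-yl in place of furan-3-yl on an aromatic carbon, the same change, at the same place, as between the first two compounds. The expected step is an at least 2.5-fold lower number from compound 3 to compound 4 (0.39 log units; beyond the scatter), resting on the measured step of an at least 3.4-fold lower number from compound 1 to compound 2 (0.53 log units; beyond the scatter). Compound 4 is therefore expected to give about 8000 nM in this assay, most likely between 2500 nM and 30000 nM.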

Compound 4, half-maximal inhibitory concentration: > 20000 nM
Compound 4 ended at the assay's limit; the forecaster's own chance of this, stated with the estimate: 40%; middle value at least 2.5-fold (0.39 log units) from the limit.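

Compound 3 and compound 4 both stand at a limit, so no step between them can be read: the limit of > 20000 nM in this assay, at which 3 of the 4 values shown sit.

Going by these compounds, whether furan-2-yl in place of furan-3-yl changes the number on the core of compound 3, as it does on the core of compound 1, stays open.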